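Aryl exchange on compound 3

A few compounds are considered here, and "the series" means these few. Any claim that something is new, unique, unknown or untested is made for them only; others in the source may bear on it.

In a toxicity assay on HaCaT cells (Homo sapiens) for cytotoxicity, read by CCK-8 assay, with a stated time of 24 h (a higher number here means that more compound is tolerated, a lower number that less compound is tolerated), compound 1 (`COc1ccccc1Oc1c(N)nc(-c2ccc(C)cc2)nc1Cl`) gives 6300 nM, compound 2 (`COc1cccc(-c2nc(N)c(Oc3ccccc3OC)c(Cl)n2)c1`) gives 14000 nM, and compound 3 (`COc1ccccc1Oc1c(N)nc(-c2ccc(C)cc2)nc1OCCO`) gives 56600 nM, the highest of the three numbers. Compound 4 (`COc1cccc(-c2nc(N)c(Oc3ccccc3OC)c(OCCO)n2)c1`) has 3-methoxyphenyl in place of the 4-methylphenyl of compound 3: 3-methoxyphenyl in place of 4-methylphenyl on an aromatic carbon. The same exchange, made with chloro in place of 2-hydroxyethoxy, gave a 2.2-fold higher number from compound 1 to compound 2 (0.35 log units; beyond the scatter), a modest step. The other measured change, 2-hydroxyethoxy in place of chloro, gave a 9.0-fold higher number from compound 1 to compound 3 (0.95 log units; beyond the scatter) and sets the starting level. Among the measured compounds shown here, no measured pair shows the exchange with 2-hydroxyethoxy present. A similar modest upward step is therefore expected in this assay, an estimated 1.9-fold higher number from compound 3 to compound 4 (0.27 log units; within the scatter). Compound 4 is estimated at 105000 nM, with an expected range of 45000 nM to 220000 nM.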

Compound 4, half-maximal cytotoxic concentration: 12700 nM
For compound 4 the middle estimate is 8.3-fold (0.92 log units) above the measured one, and the stated range ends above it.
By their numbers in this assay, from the lowest: compounds 1, 4 and 2 (each within the scatter of the next, the first and the last beyond it); then compound 3.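

With 2-hydroxyethoxy present, 3-methoxyphenyl in place of 4-methylphenyl gives a 4.5-fold lower number from compound 3 to compound 4 (0.65 log units; beyond the scatter), so this exchange keeps neither its size nor its direction across the two cores: the same change on two cores in this assay, a 2.2-fold higher number (0.35 log units; beyond the scatter) from compound 1 to compound 2 and a 4.5-fold lower number (0.65 log units; beyond the scatter) from compound 3 to compound 4, 9.9-fold (1.00 log units) apart, beyond the scatter of two such steps
With 3-methoxyphenyl present, 2-hydroxyethoxy in place of chloro gives a 1.1-fold lower number from compound 2 to compound 4 (0.04 log units; within the scatter), so the rise seen with 4-methylphenyl does not carry over: the same change on two cores in this assay, a 9.0-fold higher number (0.95 log units; beyond the scatter) from compound 1 to compound 3 and a 1.1-fold lower number (0.04 log units; within the scatter) from compound 2 to compound 4, 9.9-fold (1.00 log units) apart, beyond the scatter of two such steps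
The two positions therefore do not add independently in these four compounds, and only compound 3 stands apart from the rest.

Open, on these data alone, is whether the high number of compound 3 is specific to 4-methylphenyl or extends to other aryl groups, such as unsubstituted phenyl, paired with 2-hydroxyethoxy. Also open, as far as these compounds go, is how a longer chain or a morpholine in place of 2-hydroxyethoxy behaves with each aryl group.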